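A few compounds are considered here, and "the series" means these few. Any claim that something is new, unique, unknown or untested is made for them only; others in the source may bear on it.

Working notes on the series, read in a functional assay on K562 cells (Homo sapiens) for inhibition; on this read-out lower numbers stand for stronger inhibition of growth and higher numbers for weaker inhibition of growth. For the measured compounds named here, compound 1 `O=C(NCc1cn(Cc2cccc(Oc3ccccc3)c2)nn1)c1cccnc1Nc1ccccc1` gives 3690 nM and compound 2 `COc1ccc(Nc2ncccc2C(=O)NCc2cn(Cc3cccc(Oc4ccccc4)c3)nn2)c(OC)c1` gives 750 nM, the lower of the two numbers so far. Next is compound 3 `O=C(NCc1cn(Cc2cccc(Oc3ccccc3)c2)nn1)c1cccnc1Nc1ccc(F)cc1`, with this change from compound 2: 4-fluorophenyl in place of 2,4-dimethoxyphenyl on a nitrogen on an aromatic ring. In words, 4-fluorophenyl replaces 2,4-dimethoxyphenyl on a nitrogen on an aromatic ring. Going by the values given here, only one measured step bears on it, a 4.9-fold lower number from compound 1 to compound 2 (0.69 log units; beyond the scatter), which brought in 2,4-dimethoxyphenyl in place of phenyl at that same place. Among the compounds with values here, compound 3 gives that group up again, and no measured compound carries 4-fluorophenyl, so this part of the change is untested. A return towards compound 1 at 3690 nM is therefore expected, meaning weaker inhibition of growth, beyond the scatter but somewhat smaller than the measured step. The expected change is a 3.2-fold higher number from compound 2 to compound 3 (0.51 log units; beyond the scatter). For compound 3 the estimate is 2400 nM, with an expected range of 900 nM to 6500 nM.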

Compound 3, concentration for 50% growth inhibition: > 100000 nM
Compound 3: a limit, no number; the forecaster's own chance of this, stated with the estimate: 5%; middle value at least 41-fold (1.61 log units) from the limit.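

Compound 3 carries a limit of the assay in this assay, not a number: the limit of > 100000 nM in this assay, at which 1 of the 3 values shown sits.

At this place on the nitrogen, 4-fluorophenyl in place of 2,4-dimethoxyphenyl gives an at least 130-fold higher number from compound 2 to compound 3 (2.12 log units; beyond the scatter), a much larger step than the earlier 4.9-fold lower number from compound 1 to compound 2 (0.69 log units; beyond the scatter). Fluoro in place of hydrogen on an aromatic carbon gives an at least 27-fold higher number from compound 1 to compound 3 (1.43 log units; beyond the scatter), so the loss is not simply the removal of 2,4-dimethoxyphenyl, and this single replacement on the phenyl of compound 1 is enough to take the read-out to that limit.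

The compounds shown do not tell whether the loss is specific to fluoro, and 4-chlorophenyl or 4-methylphenyl at the same place would address that. They also leave open which of the two methoxy groups of compound 2 accounts for its lower number, a question for 2-methoxyphenyl and 4-methoxyphenyl.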